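The source may hold more compounds than are shown below. What is called first, only, known or untested is meant among the compounds shown, and "the series" means these compounds.

Measured so far in a functional assay on MDA-MB-435 cells (Homo sapiens) for inhibition, read by sulforhodamine B assay, with a stated time of 48 h; a lower number here means a stronger inhibitor, a higher number a weaker inhibitor:
compound 1 `O=C(Nc1cccc(-n2cc(-c3ccncc3)c(-c3ccc(Cl)c(O)c3)n2)c1)Nc1cccc(C(F)(F)F)c1` gives 1490 nM
compound 2 `COc1cc(-c2nn(-c3cccc(NC(=O)c4cccc(C(F)(F)F)c4)c3)cc2-c2ccncc2)ccc1Cl` gives 710 nM
compound 3 `COc1cc(-c2nn(-c3cccc(NC(=O)Nc4ccc(Cl)c(Cl)c4)c3)cc2-c2ccncc2)ccc1Cl` gives 940 nM

Compound 3 stands second highest of these three numbers; its nearest neighbour is compound 2 and its furthest is compound 1, and both gaps lie within the usual scatter, so the three sit close together. The move to compound 4 `O=C(Nc1cccc(-n2cc(-c3ccncc3)c(-c3ccc(Cl)c(O)c3)n2)c1)Nc1ccc(Cl)c(Cl)c1` is hydrogen in place of methyl on an oxygen on an aromatic ring. Among the measured compounds shown here, no measured step covers this change directly. For the measured compounds named here, the only measured step, a 1.3-fold higher number from compound 2 to compound 3 (0.12 log units; within the scatter), altered a different part of the molecule and stayed within the scatter. Compound 1, which carries the hydroxy group alongside a different urea, sits within the scatter of compound 3. The expected step of a 1.4-fold higher number from compound 3 to compound 4 (0.14 log units; within the scatter) is therefore small and not clearly beyond the scatter. Compound 4 is estimated at 1300 nM, within 500 nM to 3500 nM.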

Compound 4, half-maximal inhibitory concentration: 1100 nM
Estimate against measurement, compound 4: 1.2-fold (0.07 log units) above, within the range that was stated.
By their numbers in this assay, from the lowest: compounds 2, 3, 4 and 1 (each within the scatter of the next, the first and the last beyond it).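

Among the compounds shown here, changing methoxy to hydroxy on the 4-chloro-3-methoxyphenyl group gives the first direct reading of this swap: in this assay, a 1.2-fold higher number from compound 3 to compound 4 (0.07 log units; within the scatter) shows that the two groups cannot be told apart here. With the hydroxy group in place, changing the aryl group on the urea also makes no clear difference, as a 1.4-fold lower number from compound 1 to compound 4 (0.13 log units; within the scatter) shows. Nothing available bears on the cause of these results. Still open, as far as these compounds go, is whether an ethyl group on this oxygen, or an amine in place of the hydroxy group, would move the number beyond the scatter.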